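This account rests on a few compounds, and the source may have more. Where it says the series, first, only, none or still open, it means among the compounds named here.

Working notes on the series. The shared core of compound 1 `CC(=O)N(O)C(C)c1ccc2oc(-c3ccccc3)cc2c1` carries a 1-(acetyl(hydroxy)amino)ethyl side chain, and in an assay on RBL cells for inhibition of Polyunsaturated fatty acid 5-lipoxygenase (Rattus norvegicus) (a lower number here means a stronger inhibitor, a higher number a weaker inhibitor), compound 1 gives 490 nM. Compound 2 `COc1cccc(OC)c1C(=O)N(O)C(C)c1ccc2oc(-c3ccccc3)cc2c1` replaces the methyl on the carbonyl carbon with 2,6-dimethoxyphenyl and gives 3000 nM; compound 3 `COC(=O)CCCC(=O)N(O)C(C)c1ccc2oc(-c3ccccc3)cc2c1` extends the same position with a 3-(methoxycarbonyl)propyl chain and gives 60 nM. On these three numbers compound 1 stands second highest, with a 6.1-fold higher number from compound 1 to compound 2 (0.79 log units; beyond the scatter) and an 8.2-fold lower number from compound 1 to compound 3 (0.91 log units; beyond the scatter) placing it between the other two, and a 50-fold lower number from compound 2 to compound 3 (1.70 log units; beyond the scatter) spanning the whole range.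

Compound 4 `CC(c1ccc2oc(-c3ccccc3)cc2c1)N(O)C(N)=O` is the next variation at the carbonyl carbon: amino in place of methyl on a carbonyl carbon. Both measured steps at this position bear on it: the bulky aromatic replacement raised the number modestly, the flexible ester-bearing chain lowered it modestly. Amino is as small as the methyl it replaces and brings one hydrogen-bond donor, so neither measured step maps onto it directly; the steric weight of the aryl result is not repeated here. The expected step of a 1.6-fold lower number from compound 1 to compound 4 (0.21 log units; within the scatter) is therefore a small one, either within the scatter or a modest lowering. Compound 4 is estimated at 300 nM, with a range from 80 nM to 1200 nM.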

Compound 4, half-maximal inhibitory concentration: 410 nM
The estimate for compound 4 lay 1.4-fold (0.14 log units) below the measured number; low and high end bracket the measured number.
By their numbers in this assay, from the lowest: compound 3; then compounds 4 and 1 (each within the scatter of the next); then compound 2.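

In this assay, amino in place of methyl on the carbonyl carbon gives a 1.2-fold lower number from compound 1 to compound 4 (0.08 log units; within the scatter), so this exchange of one heavy atom, which adds one hydrogen-bond donor, separates the two compounds by no more than the scatter. Compound 4 stands apart from both larger replacements, with a 6.8-fold higher number from compound 3 to compound 4 (0.83 log units; beyond the scatter) and a 7.3-fold lower number from compound 2 to compound 4 (0.86 log units; beyond the scatter), so among the groups shown only 3-(methoxycarbonyl)propyl and 2,6-dimethoxyphenyl move the number beyond the scatter from that of compound 1. No supporting data are available to account for the amino result.

Still open, on these data alone, is whether methylamino or dimethylamino on the carbonyl carbon would stay within the scatter of compound 4. Also open, as far as these compounds go, is how a carboxylic acid in place of the methyl ester of compound 3, or a shorter or longer chain, would read.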